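Pyrrolidin-1-yl to piperidin-1-yl: working notes on the series

This account rests on a few compounds, and the source may have more. Where it says the series, first, only, none or still open, it means among the compounds named here.

In a functional assay on PC-3 cells (Homo sapiens) for antiproliferative activity, with a stated time of 72 h (on this read-out lower numbers stand for stronger inhibition and higher numbers for weaker inhibition), compound 1 (`COC(=O)CN(C)Cc1c(OC)cc(OC)c(C(=O)/C=C/c2ccccc2Cl)c1O`) gives 7200 nM and compound 2 (`COc1cc(OC)c(C(=O)/C=C/c2ccccc2Cl)c(O)c1CN1CCCC1`) gives 3100 nM. Among the measured compounds shown here, compound 2 therefore holds the lower of the only two numbers so far, and so the stronger inhibition of the pair.

Compound 3 (`COc1cc(OC)c(C(=O)/C=C/c2ccccc2Cl)c(O)c1CN1CCCCC1`) carries piperidin-1-yl in place of pyrrolidin-1-yl on a saturated chain carbon bound to an aromatic carbon. For the measured compounds named here, one measured step bears on this change: a 2.3-fold lower number from compound 1 to compound 2 (0.37 log units; beyond the scatter). It is modest and sits at the same place, with pyrrolidin-1-yl replacing ((methoxycarbonyl)methyl)(methyl)amino. Going by the values given here, no measured pair compares the five-membered and six-membered rings directly, so the data give no direction. The swap of one ring for the other is expected to move the number by less than that step, most likely by nothing beyond the scatter in this assay. The expected step is a 1.0-fold lower number from compound 2 to compound 3 (0.01 log units; within the scatter). Compound 3 is expected at 3000 nM, with an estimated range of 1400 nM to 6500 nM.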

Compound 3, half-maximal inhibitory concentration: 1700 nM
For compound 3 the middle estimate is 1.8-fold (0.25 log units) above the measured one; measured number inside the range.
By their numbers in this assay, from the lowest: compounds 3 and 2 (each within the scatter of the next); then compound 1.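

Among the compounds shown here, the first direct comparison of the two rings on a saturated chain carbon bound to an aromatic carbon gives in this assay a 1.8-fold lower number from compound 2 to compound 3 (0.26 log units; within the scatter) and so does not separate piperidin-1-yl from pyrrolidin-1-yl on this read-out. Set against ((methoxycarbonyl)methyl)(methyl)amino at the same place, piperidin-1-yl gives a 4.2-fold lower number from compound 1 to compound 3 (0.63 log units; beyond the scatter) and this step is larger than the one printed for pyrrolidin-1-yl, a 2.3-fold lower number from compound 1 to compound 2 (0.37 log units; beyond the scatter) so that both rings now stand apart from the open-chain group, with no listed compound going against that. What the numbers show is therefore a separation between the open-chain group and the two rings at this position, not one between ring sizes, and no measurement in hand offers a reason for either the separation or its size.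

A plain dimethylamino group would show whether that separation goes with the ring itself or with the methoxycarbonyl-bearing chain of compound 1, since the compounds shown cannot tell these two apart. Also open, from the compounds shown here alone, is whether a ring with a second hetero atom, such as morpholin-4-yl or piperazin-1-yl, or the larger azepan-1-yl, would stay with compound 2 and compound 3 or move towards compound 1.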